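The source may report more compounds than this note shows. Statements on the series, on what has been measured and on what is new or still open speak of the compounds shown alone.

Measured compounds:
compound 1 `C=C[C@@](C)(/C=C/c1ccc(Nc2ccc(F)c(F)c2)cc1)CCC=C(C)C` gives > 52000 nM
compound 2 `C=C[C@@](C)(/C=C/c1ccc(Nc2cc(F)c(F)cc2F)cc1)CCC=C(C)C` gives > 52000 nM
compound 3 `C=C[C@@](C)(/C=C/c1ccc(Nc2c(F)cc(F)cc2F)cc1)CCC=C(C)C` gives > 52000 nM

All three were tested in a functional assay on HepG2 cells (Homo sapiens) for cytotoxicity, with a stated time of 72 h (on this read-out higher numbers stand for an effect only at larger amounts of compound and lower numbers for an effect already at smaller amounts), and none of them yielded a number. Compound 1 gives > 52000 nM as a limit of the assay, not as a measured value. Compound 2 and compound 3 are limits too, and the whole record comes down to the limit of > 52000 nM in this assay, at which 3 of the 3 values shown sit, and nothing finer.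

The next compound, compound 4 `C=C[C@@](C)(/C=C/c1ccc(-c2cccc(F)c2)cc1)CCC=C(C)C`, differs from compound 1 in one place: 3-fluorophenyl in place of (3,4-difluorophenyl)amino on an aromatic carbon and so 3-fluorophenyl stands in place of (3,4-difluorophenyl)amino on an aromatic carbon. The measured steps offer little guidance. The first, a step that the two limits leave unreadable from compound 1 to compound 2, the second, a step that the two limits leave unreadable from compound 1 to compound 3, and the third, a step that the two limits leave unreadable from compound 2 to compound 3, have no readable size, and each only alters the fluoro pattern on the phenyl group while the nitrogen stays. Among the compounds with values here, no measured step removes that nitrogen. No step beyond the scatter is therefore expected in this assay, and no direction can be argued. The expectation rests on compound 1, whose reading of > 52000 nM is a limit. What is expected is a step that the limit leaves unreadable from compound 1 to compound 4 and probably another limit. For compound 4 the estimated value is 55000 nM with an expected range from 25000 nM to 90000 nM on this read-out.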

Compound 4, half-maximal effective concentration: > 52000 nM
Compound 4: only a limit was reported; the forecaster's own chance of this, stated with the estimate: 75%; the middle value is on the limit's open side.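

In this assay compound 4 gives > 52000 nM, which is a limit and not a measured number. No size can be read for the step between compound 1 and compound 4, as both stand at a limit: the limit of > 52000 nM in this assay, at which 4 of the 4 values shown sit. The compounds shown leave open at what concentration, if any, each of the four would show an effect in this assay.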